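This account rests on a few compounds, and the source may have more. Where it says the series, first, only, none or still open, it means among the compounds named here.

Four closely related compounds share one core, an ethyl ester and an amide held on a small saturated ring that carries a trimethoxyphenyl group. Compound 1 is `CCOC(=O)[C@@]1(C(=O)Nc2ccccc2Cl)C[C@H]1c1cc(OC)c(OC)c(OC)c1`, compound 2 is `CCOC(=O)C1(C(=O)NCc2ccc(C)cc2)CC1c1cc(OC)c(OC)c(OC)c1`, compound 3 is `CCOC(=O)[C@@]1(C(=O)NCc2ccc(C)cc2)C[C@@H]1c1cc(OC)c(OC)c(OC)c1` and the yet unmeasured compound 4 is `CCOC(=O)[C@@]1(C(=O)NCc2ccc(C)cc2)C[C@H]1c1cc(OC)c(OC)c(OC)c1`.

In a functional assay on A549 cells (Homo sapiens) for cytotoxicity, read by MTT assay, with a stated time of 48 h (a higher number here means a weaker inhibitor, a lower number a stronger inhibitor), compound 1 gives 17600 nM. In this assay compound 2 gives 18700 nM; 21400 nM (2 entries), and these repeats of compound 2 sit close together (the several entries of compound 2 in this assay, 18700 nM; 21400 nM (2 entries)). For compound 3 in this assay only a limit of the assay is known, > 100000 nM, so no single number stands for it (the limit of > 100000 nM in this assay, at which 1 of the 3 values shown sits). Compound 2 is drawn without a defined configuration where compound 3 has one (the fact that one of compounds 2 and 3 is drawn with a defined configuration and the other without, at the place where they differ).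

From compound 3 to compound 4 the change is the two compounds have the same atoms and bonds and differ only in configuration as drawn: 1 of 2 stereo elements differ; a stereocentre at a saturated ring carbon is drawn R in compound 3 and S in compound 4. For the measured compounds named here, no measured pair of this kind exists here, so the size of the expected step rests on the other compounds alone. Since compound 1 gives 17600 nM with the same drawn configuration as compound 4, and compound 2 gives 18700 nM; 21400 nM (2 entries), compound 4 is expected to gain strongly in this assay, the expected step being an at least 10-fold lower number from compound 3 to compound 4 (1.00 log units; beyond the scatter). Compound 4 is therefore estimated at 10000 nM, within the range 4000 nM to 30000 nM.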

Compound 4, half-maximal inhibitory concentration: 17100 nM
The estimate for compound 4 lay 1.7-fold (0.23 log units) below the measured number, and the stated range covers the measured number.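

In this assay, changing only how one saturated ring carbon is drawn, from R in compound 3 to S in compound 4, gives an at least 5.8-fold lower number from compound 3 to compound 4 (0.76 log units; beyond the scatter), so the activity of this series depends on the spatial arrangement at that carbon, even with the same atoms and bonds: the fact that compounds 3 and 4 differ only in the configuration as drawn. For compound 3, the entry > 100000 nM is a limit of the assay and not a number. With the drawn configuration shared by compound 1 and compound 4, 4-methylbenzyl in place of 2-chlorophenyl on an amide-type nitrogen gives a 1.0-fold lower number from compound 1 to compound 4 (0.01 log units; within the scatter), so at this configuration the two amide groups cannot be told apart in this assay, while the stereocentre change clearly can.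

It remains open whether the same ring carbon matters as much when the amide carries 2-chlorophenyl, since only the 4-methylbenzyl amide is shown with both drawings of that carbon. Also open, from the compounds shown here alone, is how a carboxylic acid in place of the ethyl ester, or a longer chain on the amide nitrogen, would behave in this assay.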